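Sulfanyl to Sulfonyl Bromophenyl Tail: Expecting Weaker Binding

A few compounds are considered here, and "the series" means these few. Any claim that something is new, unique, unknown or untested is made for them only; others in the source may bear on it.

Compound 1 `CCCCN(O)C(=O)Nc1cc([C@@H]2CC[C@@H](c3cc(OC)c(OC)c(OC)c3)O2)cc(OC)c1OCCSc1ccc(Cl)cc1` gives 20 nM in an assay for displacement of a labelled ligand from platelet-activating factor receptor (Homo sapiens); a higher number here means a weaker inhibitor, a lower number a stronger inhibitor.
Compound 2 `CCCCN(O)C(=O)Nc1cc([C@@H]2CC[C@@H](c3cc(OC)c(OC)c(OC)c3)O2)cc(OC)c1OCCS(=O)(=O)c1c(F)c(F)cc(F)c1F` gives 285 nM in this assay.
Compound 3 `CCCCN(O)C(=O)Nc1cc([C@@H]2CC[C@@H](c3cc(OC)c(OC)c(OC)c3)O2)cc(OC)c1OCCSc1cccc(Br)c1` gives 22 nM in this assay.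

Compound 3 stands second highest of the three numbers, close to compound 1 and far below compound 2. Compound 4 `CCCCN(O)C(=O)Nc1cc([C@@H]2CC[C@@H](c3cc(OC)c(OC)c(OC)c3)O2)cc(OC)c1OCCS(=O)(=O)c1ccccc1Br` differs from compound 3 by (2-bromophenyl)sulfonyl in place of (3-bromophenyl)sulfanyl on a saturated chain carbon, two bonds along the chain from an oxygen on an aromatic ring. Among the measured compounds shown here, the only measured step, a 1.1-fold higher number from compound 1 to compound 3 (0.04 log units; within the scatter), shows that exchanging one halogenated phenyl for another changed little. For the measured compounds named here, no measured step isolates the sulfanyl-to-sulfonyl part; the values of compound 2 and compound 3 simply show a markedly higher number for the compound carrying a sulfonyl. Compound 4 is therefore expected to give a higher number, a 6.8-fold higher number from compound 3 to compound 4 (0.83 log units; beyond the scatter), with an estimate of 150 nM and a range of 45 nM to 500 nM.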

Compound 4, half-maximal inhibitory concentration: 25 nM
Compound 4: middle estimate off by 6.0-fold (0.78 log units), on the high side; the measured number lies below the stated range.
By their numbers in this assay, from the lowest: compounds 1, 3 and 4 (each within the scatter of the next); then compound 2.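

In this assay a sulfonyl on this chain can bind as well as a sulfanyl, since the steps to compound 4 (a 1.1-fold higher number from compound 3 to compound 4 (0.06 log units; within the scatter); a 1.3-fold higher number from compound 1 to compound 4 (0.10 log units; within the scatter)) stay within the scatter, although each also moves the halogen. With the sulfonyl kept, the group on the sulfur matters greatly: 2-bromophenyl in place of 2,3,5,6-tetrafluorophenyl gives a large step to a lower number, meaning a stronger inhibitor (an 11-fold lower number from compound 2 to compound 4 (1.06 log units; beyond the scatter)). Nothing available explains this result.

Still open, on these data alone, is what the sulfanyl-to-sulfonyl change does alone with an unchanged phenyl group, and how a longer chain or an amine on the phenyl ring would read in this assay here.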